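A few compounds are considered here, and "the series" means these few. Any claim that something is new, unique, unknown or untested is made for them only; others in the source may bear on it.

Measured compounds:
Compound 2, `Cc1cccc(/C(N)=N/NC(=S)N2CCCC2)n1`: 17.4%
Compound 1, `N/C(=N\NC(=S)N1CCSCC1)c1ccccn1`: 16.3%

Both numbers come from a functional assay on MCF7 cells (Homo sapiens) for cytotoxicity, read by MTT assay, with a stated time of 72 h, tested at 1 uM; on this read-out higher numbers stand for more inhibition of growth at the one concentration tested and lower numbers for less inhibition of growth. Compound 2 gives the top number of the two, but compound 1 sits only slightly lower, a gap that lies within the usual scatter of this kind of measurement, so the two compounds are effectively on a par: each stops growth only modestly at the single concentration tested.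

The step of interest leads from compound 2 to compound 3, whose structure is `N/C(=N\NC(=S)N1CCCC1)c1ccccn1`. The change is small: hydrogen in place of methyl on an aromatic carbon. Put simply, a methyl group is removed from the six-membered aromatic ring with one nitrogen and a hydrogen stands in its place, leaving the rest of the molecule untouched.

Within the data shown here, no pair of measured compounds shows what this change alone does, so there is no directly comparable step to lean on. Given how close compound 1 and compound 2 already lie, and how little of the molecule is altered, the expected step from compound 2 to compound 3 is a number 1.4 percentage points lower from compound 2 to compound 3 (within the scatter), that is, nothing beyond the scatter. In this assay compound 3 is therefore estimated at 16%, with a plausible range from 7% to 26%.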

Compound 3, percent growth inhibition at one concentration: 45.9%
Beside the measured number, compound 3's estimate is 29.9 percentage points below it, and the stated range ends below it.
By their numbers in this assay, from the lowest: compounds 1 and 2 (each within the scatter of the next); then compound 3.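

In this assay, putting hydrogen in place of methyl on the aromatic carbon next to the ring nitrogen gives a number 28.5 percentage points higher from compound 2 to compound 3 (beyond the scatter), so this small change at this position clearly matters for growth inhibition at the one concentration tested. Pyrrolidin-1-yl in place of thiomorpholin-4-yl on the thiocarbonyl carbon gives a number 29.6 percentage points higher from compound 1 to compound 3 (beyond the scatter), which shows that this second place also matters and that the close numbers of compound 1 and compound 2, which differ in two places, said nothing about either place alone. Nothing available explains why either change has this effect.

On these data alone, it remains open whether any group at this ring position lowers the number or only methyl does, which a fluorine atom, a chlorine atom, a methoxy group or an ethyl group in the same place could help to show. As far as these compounds go, it is equally open whether piperidin-1-yl or morpholin-4-yl on the thiocarbonyl carbon would match pyrrolidin-1-yl, and whether the effect of the methyl group would be the same with thiomorpholin-4-yl there.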